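A Phenyl Ring Back in Place of Propyl

This account rests on a few compounds, and the source may have more. Where it says the series, first, only, none or still open, it means among the compounds named here.

Compound 3 `CCCCc1cnc(CCc2ccc(-c3ccccc3C(=O)O)cc2)[nH]1` gives 2710 nM in an in vitro functional assay on cells for agonist activity at Bombesin receptor subtype-3 (Homo sapiens), read by luminescence and calcium flux (on this read-out lower numbers stand for an effect already at smaller amounts and higher numbers for an effect only at larger amounts of compound), the highest of the three numbers shown. Its nearest neighbour is compound 2 `O=C(O)c1ccccc1-c1ccc(CCc2ncc(Cc3ccc(Cl)cc3)[nH]2)cc1` with 2290 nM; the two are separated by a 1.2-fold higher number from compound 2 to compound 3 (0.07 log units; within the scatter). Compound 1 `O=C(O)c1ccccc1-c1ccc(CCc2ncc(CC3CCOCC3)[nH]2)cc1` gives 338 nM, and the gaps a 6.8-fold higher number from compound 1 to compound 2 (0.83 log units; beyond the scatter) and an 8.0-fold higher number from compound 1 to compound 3 (0.90 log units; beyond the scatter) both lie beyond the scatter. Compound 4 `Cc1ccc(Cc2cnc(CCc3ccc(-c4ccccc4C(=O)O)cc3)[nH]2)cc1` carries 4-methylphenyl in place of propyl on a saturated chain carbon bound to an aromatic carbon. Within the data shown here, the one measured step that bears on this, a 1.2-fold higher number from compound 2 to compound 3 (0.07 log units; within the scatter), exchanged a 4-chlorophenyl for the propyl without leaving the scatter; 4-methylphenyl is a close structural relative of 4-chlorophenyl, so the return move is expected to give a 1.2-fold lower number from compound 3 to compound 4 (0.07 log units; within the scatter), nothing beyond the scatter. Compound 4 is therefore estimated at 2300 nM in this assay, with a range of 1000 nM to 5500 nM.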

Compound 4, half-maximal effective concentration: 2660 nM
Compound 4: middle estimate off by 1.2-fold (0.06 log units), on the low side; measured number inside the range.
By their numbers in this assay, from the lowest: compound 1; then compounds 2, 4 and 3 (each within the scatter of the next).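

Putting 4-methylphenyl in place of propyl at this position leaves this assay unmoved within the scatter (a 1.0-fold lower number from compound 3 to compound 4 (0.01 log units; within the scatter)), and methyl in place of chloro on an aromatic carbon does the same (a 1.2-fold higher number from compound 2 to compound 4 (0.07 log units; within the scatter)). Compounds 2, 3 and 4 thus form one group, with a chain or either substituted phenyl ring, and only the oxan-4-yl of compound 1 stands apart (a 7.9-fold higher number from compound 1 to compound 4 (0.90 log units; beyond the scatter)). No measurement shown explains this difference.

From the compounds shown here alone, whether the lower number of compound 1 depends on its ring oxygen stays open. Cyclohexyl, or piperidin-4-yl with its amine nitrogen, would put that to the test.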